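The source may hold more compounds than are shown below. What is called first, only, known or untested is meant among the compounds shown, and "the series" means these compounds.

In a functional assay on PC-12 cells (Rattus norvegicus) for cytotoxicity, read by MTT assay, with stated times of 3 h and 2 h, tested at 0.1 uM (on this read-out lower numbers stand for a weaker effect and higher numbers for a stronger effect at the one concentration tested), compound 2 `O=C(CCCCC1CCSS1)NCc1cn(CCCOc2ccc3cc(-c4ccccc4)c(=O)oc3c2)nn1` gives 33.9%, one of two measured numbers and within the scatter of compound 1 `CC(=O)c1cc2ccc(OCCCn3cc(CNC(=O)CCCCC4CCSS4)nn3)cc2oc1=O`, which gives 34.6% in this assay. Compound 3 `O=C(CCCCC1CCSS1)NCc1cn(CCCOc2ccc3cc(-c4ccc(Cl)c(Cl)c4)c(=O)oc3c2)nn1` differs from compound 2 by 3,4-dichlorophenyl in place of phenyl on an aromatic carbon. The only measured step at this position, a number 0.7 percentage points lower from compound 1 to compound 2 (within the scatter), lay within the scatter; no measured step brings chlorine onto this ring, so nothing shown points to a shift in either direction. The step is therefore expected to be a number 0.1 percentage points higher from compound 2 to compound 3 (within the scatter), nothing beyond the scatter. Compound 3 is estimated at 34%, in a range from 22% to 46%.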

Compound 3, a percentage reported as activity, at one concentration (the size of the read-out at that concentration, not a potency): 38.1%
Estimate against measurement, compound 3: 4.1 percentage points below; the range from low to high includes it.
By their numbers in this assay, from the lowest: compounds 2, 1 and 3 (each within the scatter of the next).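

In this assay, two chlorine atoms on the phenyl ring stay within the scatter (a number 4.2 percentage points higher from compound 2 to compound 3 (within the scatter)), and so does the full exchange of acetyl for 3,4-dichlorophenyl (a number 3.5 percentage points higher from compound 1 to compound 3 (within the scatter)). At this position, therefore, acetyl, phenyl and 3,4-dichlorophenyl cannot be told apart at the one concentration tested, and the substituted ring separates no better than the plain one. Nothing available explains this result. Open, as far as these compounds go, is whether an amine or a carboxylic acid here would move the read-out beyond the scatter, and whether a single chlorine matches the pair.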